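Swapping Fluoro for Methyl on a Shared Core

A few compounds are considered here, and "the series" means these few. Any claim that something is new, unique, unknown or untested is made for them only; others in the source may bear on it.

Going by the values given here, compound 1 `Clc1ccc(-c2csc(N/N=C/c3cccs3)n2)cc1` and compound 2 `Fc1ccc(-c2csc(N/N=C/c3cccs3)n2)cc1` share one core and differ only in the single group on the outer six-membered ring. In a functional assay, read by spectrophotometry, with a stated time of 15 min, tested at 20 ug/mL (on this read-out higher numbers stand for a stronger effect at the one concentration tested and lower numbers for a weaker effect), compound 1 gives 94.4%, and in this assay compound 2 gives 92.4%. Among the compounds with values here, compound 2 thus stands next to compound 1, the only other measured compound, with the two numbers too close to rank. Compound 3 `Cc1ccc(-c2csc(N/N=C/c3cccs3)n2)cc1` is reached from compound 2 by a change (methyl in place of fluoro on an aromatic carbon). Within the data shown here, only one measured step bears on it: a number 2 percentage points lower from compound 1 to compound 2 (within the scatter) came from fluoro in place of chloro on that same aromatic carbon and stayed small. No swap of fluoro for methyl has been measured, so the expectation rests on that single small step. Compound 3 is therefore expected to show a number 1.4 percentage points lower from compound 2 to compound 3 (within the scatter), with nothing beyond the scatter. The estimate for compound 3 in this assay is 91%, expected to fall between 80% and 97%.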

Compound 3, a percentage reported as inhibition, at one concentration (the size of the read-out at that concentration, not a potency): 90.9%
For compound 3 the middle estimate is 0.1 percentage points above the measured one; measured number inside the range.
By their numbers in this assay, from the lowest: compounds 3, 2 and 1 (each within the scatter of the next).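

Compound 1 and compound 2 carry a halogen on this aromatic carbon, whereas compound 3 carries a carbon group, methyl. Even so, in this assay methyl in place of fluoro gives a number 1.5 percentage points lower from compound 2 to compound 3 (within the scatter), and methyl in place of chloro gives a number 3.5 percentage points lower from compound 1 to compound 3 (within the scatter). Chloro, fluoro and methyl therefore cannot be ranked at this position, and no supporting measurement is available to explain their similar results.

As far as these compounds go, it remains open whether any group on this carbon can move the number beyond the scatter, as an amine, a carboxylic acid or a longer chain might. Each compound is read at one concentration, so these numbers show only the size of the effect at that concentration and leave open whether the three compounds would show a stronger or weaker effect at any other.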